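Moving the trifluoromethyl group on the benzyl ring

The source may hold more compounds than are shown below. What is called first, only, known or untested is meant among the compounds shown, and "the series" means these compounds.

Compound 3 `OC[C@H]1O[C@@H](n2cnc3c(NCc4cccc(C(F)(F)F)c4)ncnc32)[C@H](O)[C@@H]1O` carries a 3-(trifluoromethyl)phenyl group on a saturated chain carbon bound to a nitrogen on an aromatic ring. In a functional assay on MCF cells (Homo sapiens) for antiproliferative activity, with a stated time of 72 h (a lower number here means a stronger inhibitor, a higher number a weaker inhibitor), compound 3 reaches only the limit of the assay, > 166000 nM, and no number. Compound 1 `OC[C@H]1O[C@@H](n2cnc3c(NCc4ccccc4F)ncnc32)[C@H](O)[C@@H]1O` likewise stands at a limit in this assay, > 166000 nM. Compound 2 `OC[C@H]1O[C@@H](n2cnc3c(NCc4ccc(Cl)c(Cl)c4)ncnc32)[C@H](O)[C@@H]1O` gives a number in this assay, 88800 nM. Compound 4 `OC[C@H]1O[C@@H](n2cnc3c(NCc4ccc(C(F)(F)F)cc4)ncnc32)[C@H](O)[C@@H]1O` differs from compound 3 by 4-(trifluoromethyl)phenyl in place of 3-(trifluoromethyl)phenyl on a saturated chain carbon bound to a nitrogen on an aromatic ring. The measured steps a step that the two limits leave unreadable from compound 1 to compound 3 and an at least 1.8-fold higher number from compound 2 to compound 3 (0.27 log units; that floor lies within the scatter) bound compound 3 from one side only and concern other groups, so none speaks directly to this exchange; with the limit of > 166000 nM in this assay, at which 2 of the 3 values shown sit, the series clusters at the limit. Compound 4 is therefore expected to stay near that limit, an expected step of a number no higher from compound 3 to compound 4 (the limit leaves the size open). Compound 4 is estimated at 166000 nM, within 60000 nM to 500000 nM.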

Compound 4, half-maximal inhibitory concentration: > 166000 nM
Compound 4: only a limit was reported (the forecaster's own chance of this, stated with the estimate: 70%); the middle value lies on the limit itself.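

In this assay compound 4 also gives only a limit, > 166000 nM and no number, so exchanging 3-(trifluoromethyl)phenyl for 4-(trifluoromethyl)phenyl at this place yields no readable value, and the steps between two limits cannot be read. Among these compounds, the one readable comparison is an at least 1.8-fold higher number from compound 2 to compound 4 (0.27 log units; that floor lies within the scatter) and adds only a floor. With compound 4, the cluster at the limit grows: the limit of > 166000 nM in this assay, at which 3 of the 4 values shown sit.

As far as these compounds go, compound 2 alone gives a number, so how far the others lie past the limit stays open. Also open, from the compounds shown here alone, is whether an amine or a carboxylic acid on the benzyl ring would give a readable value.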